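Butyl ester in place of tert-butyl ester: compound 4

The compounds below may be only part of what the source reports. "The series", "measured", "known", "first", "only" and "open" are said of these compounds alone.

Compound 1 `COc1ccc(CN2C(=O)C(=O)c3cc(/C=C/C(=O)OC(C)(C)C)ccc32)cc1` gives 480 nM in a functional assay on HT-29 cells (Homo sapiens) for cytotoxicity, read by MTT assay, with a stated time of 48 h; a higher number here means a weaker inhibitor, a lower number a stronger inhibitor. Compound 2 `CC(C)(C)OC(=O)/C=C/c1ccc2c(c1)C(=O)C(=O)N2Cc1ccc(Br)cc1` gives 730 nM in this assay. Bromo in place of methoxy on an aromatic carbon moves the number by a 1.5-fold higher number from compound 1 to compound 2 (0.18 log units; within the scatter). Compound 3 `CCCCc1ccc2c(c1)C(=O)C(=O)N2` reaches only a limit, > 10000 nM in this assay, namely (the limit of > 10000 nM in this assay, at which 1 of the 3 values shown sits). Of the values shown, only compound 1 and compound 2 are numbers, and they sit within the scatter of each other. Compound 4 `CCCCOC(=O)/C=C/c1ccc2c(c1)C(=O)C(=O)N2Cc1ccc(OC)cc1` differs from compound 1 by butyl in place of tert-butyl on an oxygen next to a carbonyl group. Within the data shown here, no measured step touches the ester; the single measured step concerns the aromatic substituent and lies within the scatter, so no step beyond the scatter is expected in this assay. Compound 4 is expected to give 600 nM, between 250 nM and 1500 nM. The expected step of a 1.3-fold higher number from compound 1 to compound 4 (0.10 log units; within the scatter) is therefore within the scatter.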

Compound 4, half-maximal inhibitory concentration: 420 nM
Compound 4: middle estimate off by 1.4-fold (0.15 log units), on the high side; measured number inside the range.
By their numbers in this assay, from the lowest: compounds 4, 1 and 2 (each within the scatter of the next). At a limit, above all of these: compound 3.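

Among these compounds, this is the first measured step at the ester, and in this assay butyl in place of tert-butyl on an oxygen next to a carbonyl group stays within the scatter (a 1.1-fold lower number from compound 1 to compound 4 (0.06 log units; within the scatter)). The two esters cannot be told apart here, so for this pair the shape of the alkyl group on that oxygen makes no readable difference. Nothing measured on these compounds accounts for this result.

Open, as far as these compounds go, is whether a carboxylic acid, an amide or a longer chain at this position would read the same. Also open, from the compounds shown here alone, is whether bromo in place of methoxy on an aromatic carbon behaves alike with the butyl ester.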